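The source may hold more compounds than are shown below. What is called first, only, known or untested is meant among the compounds shown, and "the series" means these compounds.

Measured so far:
- Compound 1, `CCN(CC)S(=O)(=O)c1ccc(S(=O)(=O)N2CCC[C@@H](C(=O)N(C)C(C)C)C2)cc1`: 6200 nM
- Compound 2, `CCN(CC)S(=O)(=O)c1ccc(S(=O)(=O)N2CCC[C@@H](C(=O)NC3CN(C(=O)C4CC4)C3)C2)cc1`: 2800 nM

Both numbers come from a functional assay on MIA PaCa-2 cells (Homo sapiens) for inhibition, read by MTT assay, with a stated time of 7 days; on this read-out lower numbers stand for stronger inhibition and higher numbers for weaker inhibition. Among the measured compounds shown here, compound 2 gives the lowest of the two numbers; its nearest neighbour is compound 1, and the only step between them, a 2.2-fold lower number from compound 1 to compound 2 (0.35 log units; beyond the scatter), is the one change on record: a tertiary amide, isopropyl(methyl)amino, was exchanged for a secondary amide carrying a ring.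

Compound 3, `CCN(CC)C(=O)[C@@H]1CCCN(S(=O)(=O)c2ccc(S(=O)(=O)N(CC)CC)cc2)C1`, carries the same core and differs from compound 2 in one place: diethylamino in place of (1-(cyclopropylcarbonyl)azetidin-3-yl)amino on a carbonyl carbon. Diethylamino resembles the isopropyl(methyl)amino of compound 1 more than the ring-bearing group of compound 2, since both are dialkylamino groups without a donor or a ring. For the measured compounds named here, the one step that bears on this change, from compound 1 to compound 2, was modest, and running it back in the other direction suggests a similarly modest move toward the number of compound 1. Compound 3 is therefore expected to show a step of about a 2.0-fold higher number from compound 2 to compound 3 (0.29 log units; within the scatter) in this assay, the number rising rather than falling. The estimate for compound 3 is 5500 nM, with a range from 2500 nM to 12000 nM.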

Compound 3, half-maximal inhibitory concentration: 6400 nM
Estimate against measurement, compound 3: 1.2-fold (0.07 log units) below; the measured number falls inside the stated range.
By their numbers in this assay, from the lowest: compound 2; then compounds 1 and 3 (each within the scatter of the next).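

In this assay, the step of a 2.3-fold higher number from compound 2 to compound 3 (0.36 log units; beyond the scatter) shows that the edge of the larger group is not tied to isopropyl(methyl)amino alone: a second dialkylamino group, diethylamino, also gives a higher number than (1-(cyclopropylcarbonyl)azetidin-3-yl)amino on this carbonyl carbon. The step of a 1.0-fold higher number from compound 1 to compound 3 (0.01 log units; within the scatter) adds that the two small dialkylamino groups cannot be told apart in this assay, so exchanging one for the other makes no visible difference here. Nothing available explains the gap between these small groups and the larger ring-bearing group.

The compounds shown leave open which part of the larger group matters, as it differs from both dialkylamino groups in its two rings, its size and its amide hydrogen all at once. Isopropylamino, which keeps the amide hydrogen but carries no ring, would help to separate these features, and whether any group on this carbonyl carbon can bring the number far lower also remains unanswered.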